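Acyl exchange on the ester: cycloheptyl to 2-phenylethenyl

The source may report more compounds than this note shows. Statements on the series, on what has been measured and on what is new or still open speak of the compounds shown alone.

Values in an in vivo functional assay on the whole organism (MDA-MB-435 cells, Homo sapiens) for antiproliferative activity; a higher number here means a weaker inhibitor, a lower number a stronger inhibitor:
compound 1 `CCCCCc1ccc(C(=O)O[C@@H]2CCC(NC(=O)[C@H](OC)[C@H](O)[C@@H](O)[C@H](O)/C=C/C(C)(C)C)C(=O)NC2)cc1`: 20 nM
compound 2 `CO[C@@H](C(=O)NC1CC[C@@H](OC(=O)Cc2cccnc2)CNC1=O)[C@H](O)[C@@H](O)[C@H](O)/C=C/C(C)(C)C`: 5850 nM
compound 3 `CO[C@@H](C(=O)NC1CC[C@@H](OC(=O)C2CCCCCC2)CNC1=O)[C@H](O)[C@@H](O)[C@H](O)/C=C/C(C)(C)C`: 20 nM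

Compound 3 stands level with compound 1, the two together holding the lowest of the three numbers, with compound 2 far off. Compound 4 `CO[C@@H](C(=O)NC1CC[C@@H](OC(=O)/C=C/c2ccccc2)CNC1=O)[C@H](O)[C@@H](O)[C@H](O)/C=C/C(C)(C)C` carries 2-phenylethenyl in place of cycloheptyl on a carbonyl carbon. Like cycloheptyl, the entering group is carbon only, with no net charge.

Within the data shown here, two measured steps bear on this change. Exchanging 4-pentylphenyl for cycloheptyl gives no change at the digits printed from compound 1 to compound 3 (within the scatter), so two quite different carbon-only groups read alike. Exchanging (pyridin-3-yl)methyl for cycloheptyl gives a 290-fold lower number from compound 2 to compound 3 (2.47 log units; beyond the scatter), the only large move in the set. With three compounds this is a thin basis, but the group on compound 4 is also carbon only, so it is expected to read with compound 1 and compound 3 rather than with compound 2. In this assay the expected change is a 1.5-fold higher number from compound 3 to compound 4 (0.18 log units; within the scatter), which is no step beyond the scatter. For compound 4 the estimated value is 30 nM, with an expected range of 8 nM to 200 nM.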

Compound 4, half-maximal inhibitory concentration: 20 nM
Compound 4: middle estimate off by 1.5-fold (0.18 log units), on the high side; the range from low to high includes it.
By their numbers in this assay, from the lowest: compounds 1, 3 and 4 (each within the scatter of the next); then compound 2.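

In this assay the step of no change at the digits printed from compound 3 to compound 4 (within the scatter) and the step of no change at the digits printed from compound 1 to compound 4 (within the scatter) put 2-phenylethenyl with cycloheptyl and 4-pentylphenyl, so three carbon-only groups on this carbonyl carbon now read alike. An aromatic ring and a double bond outside aromatic rings, entering where a seven-membered non-aromatic ring stood, thus leave the number within the scatter in this pair. The step of a 290-fold lower number from compound 2 to compound 4 (2.47 log units; beyond the scatter) shows the same large size as the one to compound 3, which leaves compound 2 as the only one apart in this set, and no measurement shown gives a reason for that gap.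

A phenylmethyl group on this carbonyl carbon would show whether the gap of compound 2 follows the pyridine nitrogen or the methylene link. As far as these compounds go, an amine or a carboxylic acid on the phenyl ring of 2-phenylethenyl also remains open, as does an acyl group with a short unbranched chain.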